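The source may hold more compounds than are shown below. What is called first, only, known or untested is meant among the compounds shown, and "the series" means these compounds.

Measured compounds:
Compound 1 `CCn1c(C(=O)NCCN(C)C)ccc1C(CC)(CC)c1ccc(OCCC(O)(CC)CC)c(C)c1`: 870 nM
Compound 2 `CCn1c(C(=O)NCCN)ccc1C(CC)(CC)c1ccc(OCCC(O)(CC)CC)c(C)c1`: 2420 nM
Compound 3 `CCOc1ccc(NC(=O)c2ccc(C(CC)(CC)c3ccc(OCCC(O)(CC)CC)c(C)c3)n2CC)cc1`: a limit of the assay, > 50000 nM

All three share one core and differ only in the group carried on the amide-type nitrogen. In a functional assay on PC-3 cells (Homo sapiens) for antiproliferative activity, read by MTT assay, with a stated time of 48 h (on this read-out higher numbers stand for weaker inhibition and lower numbers for stronger inhibition), compound 1 stands lowest of the two numbers measured outright, with compound 2 the nearer neighbour. For compound 3 the result is only a limit: the limit of > 50000 nM in this assay, at which 1 of the 3 values shown sits.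

Compound 4 `CCn1c(C(=O)NC(CO)CCO)ccc1C(CC)(CC)c1ccc(OCCC(O)(CC)CC)c(C)c1` is not yet measured. It differs from compound 1 in one place: 3-hydroxy-1-(hydroxymethyl)propyl in place of 2-(dimethylamino)ethyl on an amide-type nitrogen. Two measured steps at this same nitrogen bear on the change. Swapping the dimethylamino for an amino gave a modest step, a 2.8-fold higher number from compound 1 to compound 2 (0.44 log units; beyond the scatter). Replacing the whole chain with 4-ethoxyphenyl gave a large one, an at least 57-fold higher number from compound 1 to compound 3 (1.75 log units; beyond the scatter). Compound 4 keeps a short chain but carries two hydroxyls in place of the amine, so a weakening larger than the first step and smaller than the second is expected, that is a 5.7-fold higher number from compound 1 to compound 4 (0.76 log units; beyond the scatter). Compound 4 is therefore expected to give about 5000 nM, within a range from 1500 nM to 20000 nM.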

Compound 4, half-maximal inhibitory concentration: 8760 nM
Compound 4: middle estimate off by 1.8-fold (0.24 log units), on the low side; low and high end bracket the measured number.
By their numbers in this assay, from the lowest: compound 1; then compound 2; then compound 4. At a limit, above all of these: compound 3.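

In this assay, a chain with no amine on the amide-type nitrogen still gives a measured number, but a higher one than either amine-bearing chain, with a 10-fold higher number from compound 1 to compound 4 (1.00 log units; beyond the scatter) and a 3.6-fold higher number from compound 2 to compound 4 (0.56 log units; beyond the scatter). The same 3-hydroxy-1-(hydroxymethyl)propyl chain nevertheless does better than 4-ethoxyphenyl on this nitrogen, with an at least 5.7-fold lower number from compound 3 to compound 4 (0.75 log units; beyond the scatter). That comparison has only one measured end, as compound 3 gives a limit rather than a number: the limit of > 50000 nM in this assay, at which 1 of the 4 values shown sits.

The compounds shown leave open how a simple 2-hydroxyethyl chain would compare, and so whether one hydroxyl would serve as well as the pair in compound 4. They also leave open whether a longer chain carrying dimethylamino, or a chain carrying a carboxylic acid, would give a lower or higher number than compound 1.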